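The compounds below may be only part of what the source reports. "The series", "measured", "known", "first", "only" and "open" are said of these compounds alone.

Compound 1 `CCCCC(=O)O[C@H]1C[C@@H](C)C=C2C=C[C@H](C)[C@H](CC[C@@H]3C[C@@H](O)CC(=O)O3)C21`: 8.7 nM
Compound 2 `C[C@H]1C=C2C=C[C@H](C)[C@H](CC[C@@H]3C[C@@H](O)CC(=O)O3)C2[C@@H](OC(=O)C(C)(C)C)C1`: 2.7 nM

In an assay for inhibition of 3-hydroxy-3-methylglutaryl-coenzyme A reductase (Rattus norvegicus) (a lower number here means a stronger inhibitor, a higher number a weaker inhibitor), compound 2 holds the lower of the two numbers, and the step of a 3.2-fold lower number from compound 1 to compound 2 (0.51 log units; beyond the scatter) lies beyond the scatter. Compound 3 `C[C@H]1C=C2C=C[C@H](C)[C@H](CC[C@@H]3C[C@@H](O)CC(=O)O3)C2[C@@H](OC(=O)Oc2ccccc2)C1` carries the change (phenoxy in place of tert-butyl on a carbonyl carbon). Among the measured compounds shown here, the only measured step, a 3.2-fold lower number from compound 1 to compound 2 (0.51 log units; beyond the scatter), exchanged one chain for another on that carbonyl carbon; nothing measured here covers a phenoxy group at that place, so the direction is uncertain. Compound 3 is therefore expected to remain close to its parent, with a step of a 1.5-fold higher number from compound 2 to compound 3 (0.17 log units; within the scatter) that stays within the scatter. Compound 3 is estimated at 4 nM, with a range from 1.5 nM to 12 nM.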

Compound 3, half-maximal inhibitory concentration: 83 nM
Estimate against measurement, compound 3: 21-fold (1.32 log units) below; the whole stated range lies below it.
By their numbers in this assay, from the lowest: compound 2; then compound 1; then compound 3.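

On the carbonyl carbon, phenoxy is tolerated far less well than either chain in this assay, with a 31-fold higher number from compound 2 to compound 3 (1.49 log units; beyond the scatter) and a 9.5-fold higher number from compound 1 to compound 3 (0.98 log units; beyond the scatter). The earlier step exchanged only one carbon chain for another, whereas this change brings in an aromatic ring and an oxygen together, and it costs much more than that exchange gained. No available evidence bears on the cause of this loss. The compounds shown leave open whether the ring or the oxygen accounts for the loss, which a phenyl or benzyl group on that carbonyl carbon would help separate.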